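From diisopropylamino to pyrrolidin-1-yl on the carbonyl carbon

This account rests on a few compounds, and the source may have more. Where it says the series, first, only, none or still open, it means among the compounds named here.

In an ADME assay (liver) for metabolic stability, with Liver microsome (Homo sapiens) as the target, using microsomes (on this read-out higher numbers stand for a longer-lived compound and lower numbers for a shorter-lived compound), compound 1 `CC(C)N(C(=O)n1cnc(S[C@@H]2C[C@H]3CC[C@@H]2C3)n1)C(C)C` gives 0.372 h. Within the data shown here, this is the only actual number so far, so compound 1 serves as the reference point, with nothing yet to rank it against. Compound 2 `O=C(N1CCCC1)n1cnc(S(=O)(=O)[C@@H]2C[C@H]3CC[C@@H]2C3)n1` reads > 0.5 h, which is a limit of the assay and not a number.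

The next compound to be read is compound 3 `O=C(N1CCCC1)n1cnc(S[C@@H]2C[C@H]3CC[C@@H]2C3)n1`. It keeps the core of compound 1 and carries pyrrolidin-1-yl in place of diisopropylamino on a carbonyl carbon. Among the measured compounds shown here, no measured pair isolates this change, so there is no direct precedent for its size or direction in this assay.

The expected result, a 1.1-fold higher number from compound 1 to compound 3 (0.03 log units; within the scatter), is a step that stays within the usual scatter, with no firm direction. The range is kept wide, and its upper end extends past the limit seen for compound 2, since the reference value for compound 1 sits close to that limit. Compound 3 is estimated at 0.4 h, with an expected range from 0.2 h to 0.75 h.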

Compound 3, half-life: > 0.5 h
Compound 3: no number, only a limit; the forecaster's own chance of this, stated with the estimate: 25%; at least 1.2-fold (0.09 log units) between middle value and limit.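

In this assay the carbonyl carbon now has its first readable step: pyrrolidin-1-yl in place of diisopropylamino gives an at least 1.3-fold higher number from compound 1 to compound 3 (0.12 log units; that floor lies within the scatter) and so fixes a floor for the change, with no upper bound. Compound 3 carries a limit and not a number. The true size of the step stays hidden, and a small gain cannot be told from a large one, because the read-out stops at a limit: the limit of > 0.5 h in this assay, at which 2 of the 3 values shown sit.

From the compounds shown here alone, compound 2 and compound 3 both stand as limits, so the step between them cannot be read, and the effect of the sulfur oxidation state on this read-out remains unknown. Also open, going by these compounds, is whether the ring of pyrrolidin-1-yl or simply the loss of the branched chains carries the step, a question that an open-chain diethylamino or a ring such as piperidin-1-yl or morpholin-4-yl on the same carbonyl carbon could separate, provided the values fall short of the limit.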